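The compounds below may be only part of what the source reports. "The series", "measured", "known", "first", "only" and "open" are said of these compounds alone.

Working notes on the step from compound 1 to compound 3 in a functional assay on SW-620 cells (Homo sapiens) for antiproliferative activity, read by MTT assay, with a stated time of 72 h; on this read-out lower numbers stand for stronger inhibition and higher numbers for weaker inhibition. Among the measured compounds shown here, compound 1 `CCCCCc1ccc(-c2cn(C[C@H](O)[C@H]3OC(=O)C(OCc4ccccc4)=C3OCc3ccccc3)nn2)cc1` carries the only numeric reading of the set: in this assay compound 1 gives 12200 nM. The other measured member, compound 2 `COc1ccc(-c2cn(C/C=C3\OC(=O)C(OCc4ccccc4)=C3OCc3ccccc3)nn2)cc1`, returns a limit of the assay and not a number; in this assay compound 2 gives > 100000 nM. Among the values shown, one sits at the limit of > 100000 nM in this assay, at which 1 of the 2 values shown sits. For the measured compounds named here, compound 2 differs from compound 1 in more than one place, so no counted step joins them, and the pair shows only a weak numeric value beside a limit.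

Compound 3 `O=C1O[C@H]([C@@H](O)Cn2cc(CCO)nn2)C(OCc2ccccc2)=C1OCc1ccccc1` is not yet measured. It is reached from compound 1 by the change (2-hydroxyethyl in place of 4-pentylphenyl on an aromatic carbon). Going by the values given here, no step between measured compounds covers a change of this kind, so its size is not anchored by the data. The expectation is a move toward weaker inhibition beyond the usual scatter, with a real chance that this assay reports only a limit. The step expected from compound 1 to compound 3 is a 4.1-fold higher number from compound 1 to compound 3 (0.61 log units; beyond the scatter). For compound 3 the estimate in this assay is 50000 nM, within 15000 nM to 150000 nM.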

Compound 3, half-maximal inhibitory concentration: > 100000 nM
Compound 3 was reported as a limit (the forecaster's own chance of this, stated with the estimate: 40%); at least 2.0-fold (0.30 log units) between middle value and limit.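

At this position on the five-membered aromatic ring with 3 nitrogen, this assay now has its first counted step: 2-hydroxyethyl in place of 4-pentylphenyl gives an at least 8.1-fold higher number from compound 1 to compound 3 (0.91 log units; beyond the scatter). Compound 3 reads only as a limit of the assay, so this step fixes a minimum size and not a true size, yet it already shows that the numeric reading of compound 1 does not survive this exchange on an aromatic carbon. Compound 3 shares its limit with compound 2, which leaves compound 1 as the only numeric anchor of the set: the limit of > 100000 nM in this assay, at which 2 of the 3 values shown sit.

The single step changes several things at once, removing the six-membered aromatic ring and the pentyl chain and bringing in a hydrogen-bond donor and acceptor, so the compounds shown cannot say which of these matters. An unsubstituted phenyl, a plain octyl chain or a chain ending in an amine on the same aromatic carbon would pull these apart, and would show whether the ring, the length of the chain or the end group carries the reading of compound 1.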